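The source may report more compounds than this note shows. Statements on the series, on what has been measured and on what is new or still open speak of the compounds shown alone.

Measured in a functional assay on A549 cells (Homo sapiens) for antiproliferative activity, read by MTT assay, with a stated time of 72 h; a lower number here means a stronger inhibitor, a higher number a weaker inhibitor:
- compound 1 `COc1cc(-n2cnc3ccc(-c4cc(F)ccc4F)cc32)cc(OC)c1OC`: 7940 nM
- compound 2 `COc1cc(-n2cnc3ccc(-c4cccc(O)c4)cc32)cc(OC)c1OC`: 250 nM

Of these two numbers, compound 2 has the lower, at 250 nM, which makes it the stronger inhibitor of the pair. The next compound to be tested is compound 3 `COc1cc(-n2cnc3ccc(-c4cccc([N+](=O)[O-])c4)cc32)cc(OC)c1OC`. It keeps the rest of compound 2 and changes one group: nitro in place of hydroxy on an aromatic carbon. The new group sits on an aromatic carbon, meta to a large group.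

For the measured compounds named here, only one measured step bears on this change: a 32-fold lower number from compound 1 to compound 2 (1.50 log units; beyond the scatter). That step is large and shows that the substituents on this outer ring can matter greatly in this assay. Going by the values given here, it says little about nitro itself, since no nitro compound has been measured yet. Among the compounds with values here, compound 1, the only measured compound without hydroxy, gives 7940 nM, so a higher number is the more likely direction, though one comparison is thin evidence. The expected change is a 4.0-fold higher number from compound 2 to compound 3 (0.60 log units; beyond the scatter), estimated to be smaller than the measured step. For compound 3 the expected value is 1000 nM, with an estimated range from 200 nM to 5000 nM.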

Compound 3, half-maximal inhibitory concentration: 5410 nM
Compound 3: the middle estimate sits 5.4-fold (0.73 log units) below what was measured; the whole stated range lies below it.
By their numbers in this assay, from the lowest: compound 2; then compounds 3 and 1 (each within the scatter of the next).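

In this assay, nitro in place of hydroxy on this aromatic carbon gives a 22-fold higher number from compound 2 to compound 3 (1.34 log units; beyond the scatter) and is a large step, so the change of this one group alone is enough to lose most of the activity seen with compound 2. The second comparison, a 1.5-fold lower number from compound 1 to compound 3 (0.17 log units; within the scatter) and within the scatter, means that the 3-nitrophenyl and 2,5-difluorophenyl groups cannot be told apart in this assay, which leaves the 3-hydroxyphenyl group as the only one of the three outer rings shown that gives a clearly lower number. No measured evidence here explains why hydroxy stands apart from the other two groups.

Going by these compounds, it remains open whether other groups on this carbon, such as an amine or a carboxylic acid, would give a number close to that of compound 2 at 250 nM or one closer to the other two compounds. Also open is whether hydroxy would keep this advantage on a different carbon of the same ring, as it appears at only one place in the compounds shown.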